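The compounds below may be only part of what the source reports. "The series", "measured", "known", "first", "only" and "open" are said of these compounds alone.

The study sets out two measured compounds and one that awaits its result in an assay on isolated protein for inhibition of Apoptosis regulator Bcl-2 (Homo sapiens), read by fluorescence polarization, with stated times of 5 min and 10 min; on this read-out lower numbers stand for stronger inhibition and higher numbers for weaker inhibition. Among the measured compounds shown here, compound 1, `CONC(=O)[C@@H]1CC=C(CCC=C(C)C)C[C@H]1c1ccccc1`, is the only one that gives a number: in this assay compound 1 gives 2700 nM. Compound 2, `CC1(C)CCCC2=C1C[C@@H](C(=O)O)[C@H](c1ccccc1)C2`, carries a different core. In this assay, for the measured compounds named here, compound 2 reaches only a limit of the assay, > 23000 nM, and it is the one value sitting at the limit of > 23000 nM in this assay, at which 1 of the 2 values shown sits. Going by the values given here, no step between the two measured compounds is drawn, and their values show only that compound 1 has a number where compound 2 has none. Compound 3, `COC(=O)CCNC(=O)[C@@H]1CC=C(CCC=C(C)C)C[C@H]1c1ccccc1`, keeps the core of compound 1 and differs from it at the amide: 2-(methoxycarbonyl)ethyl in place of methoxy on an amide-type nitrogen. The place is an amide-type nitrogen whose other neighbours are a carbonyl carbon. Among the compounds with values here, with no measured step to lean on, the change is expected to move the inhibition constant little, a shift that, if any, leans toward weaker inhibition and barely past the scatter; the expected step is a 1.3-fold higher number from compound 1 to compound 3 (0.11 log units; within the scatter). Compound 3 is therefore estimated at 3500 nM, within a range from 1200 nM to 12000 nM.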

Compound 3, inhibition constant: > 23000 nM
Compound 3 gave a limit, no number; the forecaster's own chance of this, stated with the estimate: 10%; at least 6.5-fold (0.81 log units) between middle value and limit.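

At this place, the amide-type nitrogen, the first measured change is far from neutral: in this assay the 2-(methoxycarbonyl)ethyl group in place of methoxy gives an at least 8.5-fold higher number from compound 1 to compound 3 (0.93 log units; beyond the scatter) and so removes the measurable inhibition that compound 1 had shown. Compound 3 gives > 23000 nM, which is a limit of the assay and not a number, so the step fixes only a lower bound on the size of the change and not its full extent. Among the compounds shown here, compound 1 is thus the only compound with a number, and the two other values shown end at the same limit of the assay: the limit of > 23000 nM in this assay, at which 2 of the 3 values shown sit.

For the compounds shown here, what remains open is whether the loss follows the length of the chain or its methoxycarbonyl end, since the single step changes both at once, and a plain ethyl, a chain ending in a carboxylic acid or one ending in an amine on the same nitrogen would separate the two. Also open, on these data alone, is what the methoxy itself contributes, which a hydroxy or a plain hydrogen at that nitrogen would address.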